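A few compounds are considered here, and "the series" means these few. Any claim that something is new, unique, unknown or untested is made for them only; others in the source may bear on it.

Working notes on the series, in a functional assay on CRL2813 cells (Homo sapiens) for cytotoxicity, read by sulforhodamine B assay, with a stated time of 5 days; on this read-out lower numbers stand for stronger inhibition and higher numbers for weaker inhibition.

Compound 1, `Cc1ccc(NC(=O)N[C@H]2CC[C@H](Oc3ccc(F)cc3)CC2)cc1`, sits at the limit of this assay: in this assay compound 1 gives > 20000 nM, which is a limit and not a number. This is the limit of > 20000 nM in this assay, at which 1 of the 2 values shown sits. Compound 2, `O=C(Nc1cccc(C(F)(F)F)c1)N[C@H]1CCC[C@H](Oc2ccc(C(F)(F)F)cc2)C1`, carries a trifluoromethyl on each aryl and a different ring size in the core; in this assay compound 2 gives 3800 nM. Going by the values given here, no single-point step between compound 1 and compound 2 is available, so the two values are only recorded side by side.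

Compound 3, `CSc1ccc(NC(=O)N[C@H]2CC[C@H](Oc3ccc(F)cc3)CC2)cc1`, is still to be measured. It differs from compound 1 by methylsulfanyl in place of methyl on an aromatic carbon. The step from compound 1 to compound 3 is expected to be small, a step that the limit leaves unreadable from compound 1 to compound 3, with no clear direction beyond the usual scatter. Compound 3 is therefore estimated at 25000 nM in this assay, within a range of 8000 nM to 80000 nM, and it may well again return only a limit.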

Compound 3, half-maximal inhibitory concentration: > 20000 nM
Compound 3 gave a limit, no number (the forecaster's own chance of this, stated with the estimate: 65%); the middle value does not contradict the limit.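

No step can be read from compound 1 to compound 3, as each gives only a limit and not a number: the limit of > 20000 nM in this assay, at which 2 of the 3 values shown sit.

The compounds shown leave open whether methylsulfanyl in place of methyl on an aromatic carbon changes the read-out at all.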